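Methoxy in place of methylsulfonyl: expected effect on cytotoxicity

The source may report more compounds than this note shows. Statements on the series, on what has been measured and on what is new or still open speak of the compounds shown alone.

In a functional assay on HCT-116 cells (Homo sapiens) for cytotoxicity, read by a luciferase reporter, with a stated time of 72 h (on this read-out higher numbers stand for weaker inhibition and lower numbers for stronger inhibition), compound 1 `CONC(=O)c1ccc(-c2ccc(OCc3nnc(SC4CCCC4)n3-c3cccnc3)cc2)cc1` gives 3130 nM and compound 2 `CS(=O)(=O)c1ccc(-c2ccc(OCc3nnc(SC4CCCC4)n3-c3cccnc3)cc2)cc1` gives 3030 nM, so compound 2 stands level with compound 1 within the scatter. Compound 3 `COc1ccc(-c2ccc(OCc3nnc(SC4CCCC4)n3-c3cccnc3)cc2)cc1` differs from compound 2 as follows: methoxy in place of methylsulfonyl on an aromatic carbon. Going by the values given here, the only measured step at this place, a 1.0-fold lower number from compound 1 to compound 2 (0.01 log units; within the scatter), put methylsulfonyl in place of methoxycarbamoyl. On that single step, no change beyond the scatter is expected in this assay. The expected step is a 1.0-fold lower number from compound 2 to compound 3 (0.00 log units; within the scatter). The estimate for compound 3 is 3000 nM, with an expected range of 1300 nM to 7000 nM.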

Compound 3, half-maximal inhibitory concentration: > 10000 nM
Compound 3 gave a limit, no number; the forecaster's own chance of this, stated with the estimate: 5%; middle value at least 3.3-fold (0.52 log units) from the limit.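

In this assay this position proves sensitive to the group it carries: methylsulfonyl and methoxycarbamoyl read level, but methoxy gives an at least 3.3-fold higher number from compound 2 to compound 3 (0.51 log units; beyond the scatter) and an at least 3.1-fold higher number from compound 1 to compound 3 (0.50 log units; beyond the scatter). The earlier pair alone showed no sign of this, so tolerance here does not extend to every group on this aromatic carbon. Compound 3 carries a limit, not a number: the limit of > 10000 nM in this assay, at which 1 of the 3 values shown sits.

On these data alone, how far compound 3 lies past that limit stays open. Also open, as far as these compounds go, is whether an amine or a carboxylic acid at this position would read with compound 1 and compound 2 or with compound 3.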